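This account rests on a few compounds, and the source may have more. Where it says the series, first, only, none or still open, it means among the compounds named here.

Compound 1 `COC(=O)c1cc(C2=C(c3cc(OC)c(OC)c(OC)c3)C(=O)CC2O[SiH2]C(C)(C)C)ccc1OC` was examined in an ADME assay on KB cells (Homo sapiens) for cytotoxicity, read by MTT assay, with a stated time of 72 h (a higher number here means a weaker inhibitor, a lower number a stronger inhibitor), and returned only a limit of the assay, > 100 ug/mL. Compound 2 `COc1ccc(C2=C(c3cc(OC)c(OC)c(OC)c3)C(=O)C(O)C2)cc1NC(=O)c1ccccc1` likewise returned only a limit in this assay, > 100 ug/mL. For compound 3 `COc1ccc(C2=C(c3cc(OC)c(OC)c(OC)c3)C(=O)CC2O)cc1` this assay shows "not determined" (no result reported). Compound 1 therefore stands at the limit of > 100 ug/mL in this assay, at which 2 of the 3 values shown sit, with no number of its own. The unmeasured compound 4 `COc1cc(C2=C(c3cc(C)c(OC)c(C)c3)C(O[SiH2]C(C)(C)C)CC2=O)cc(OC)c1OC` differs from compound 1 by 4-methoxy-3,5-dimethylphenyl in place of 4-methoxy-3-(methoxycarbonyl)phenyl on a double-bonded ring carbon. For the measured compounds named here, no measured pair of compounds here shares that change, so the two limits are all there is to go on. In this assay the expected step is a step that the limit leaves unreadable from compound 1 to compound 4, nothing beyond the scatter. Compound 4 is thus estimated at 120 ug/mL in this assay, between 30 ug/mL and 300 ug/mL, and most likely it will again be reported only as a limit.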

Compound 4, half-maximal inhibitory concentration: 40 ug/mL
Beside the measured number, compound 4's estimate is 3.0-fold (0.48 log units) above it; the range from low to high includes it.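

In this assay, 4-methoxy-3,5-dimethylphenyl in place of 4-methoxy-3-(methoxycarbonyl)phenyl on a double-bonded ring carbon gives an at least 2.5-fold lower number from compound 1 to compound 4 (0.39 log units; beyond the scatter). For the compounds shown here, this shows that the group at this position can move the read-out, which the earlier compounds did not show. Compound 4 is the first here with a number of its own, and the true size of the step stays unknown, as the comparison starts from a limit: the limit of > 100 ug/mL in this assay, at which 2 of the 4 values shown sit.

The compounds shown do not separate the loss of the methoxycarbonyl group from the arrival of the methyl groups. On these data alone, how a carboxylic acid or an amine on this ring would read also remains open.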